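Chain Substituent Swap on the Pyridazinone Series: Notes

The source may report more compounds than this note shows. Statements on the series, on what has been measured and on what is new or still open speak of the compounds shown alone.

In a functional assay on the whole organism (stomach) for inhibition, with Rattus norvegicus as the target, at a dose of 100 mg/kg by the intraduodenal route (a lower number here means less inhibition, a higher number more inhibition at the dose given (going by the name of the read-out)), compound 1 `Cc1cc(-c2ccccc2)nn(CCC(=N)S)c1=O` gives 60.2% and compound 2 `CCOC(=O)CCn1nc(-c2ccccc2)ccc1=O` gives 6.3%. Compound 2 stands at the lower of the two numbers recorded so far; the nearest compound, compound 1, sits higher by a margin beyond the scatter. No step between measured compounds differing in one place is available, so the two values are recorded side by side without any cause being read into the gap.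

Compound 3 `N=C(S)CCn1nc(-c2ccccc2)ccc1=O` is the unmeasured analogue of compound 2. It differs from compound 2 as follows: a group of 3 heavy atoms (1 carbon, 1 nitrogen, 1 sulfur; no ring) in place of a group of 5 heavy atoms (3 carbon, 2 oxygen; no ring), on a saturated chain carbon, two bonds along the chain from an aromatic nitrogen. The entering group is the same group of 3 heavy atoms (1 carbon, 1 nitrogen, 1 sulfur) that compound 1 carries on its own chain.

A step upward, beyond the scatter, is expected in this assay, because compound 1 carrying this group gives 60.2% while compound 2 gives 6.3%. Compound 3 is therefore estimated at 42%, with a range from 12% to 70%. The expected step is a number 35.7 percentage points higher from compound 2 to compound 3 (beyond the scatter); the cores differ, so the range is kept wide.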

Compound 3, a percentage reported as inhibition, in the whole organism at one dose (the size of the read-out at that dose, not a potency): 53.7%
For compound 3 the middle estimate is 11.7 percentage points below the measured one; low and high end bracket the measured number.
By their numbers in this assay, from the lowest: compound 2; then compounds 3 and 1 (each within the scatter of the next).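

In this assay, the change on a saturated chain carbon, two bonds along the chain from an aromatic nitrogen, can now be read on a shared core: with ethoxycarbonyl leaving and the group of 3 heavy atoms (1 carbon, 1 nitrogen, 1 sulfur) entering, the step is a number 47.4 percentage points higher from compound 2 to compound 3 (beyond the scatter), a large one. The second step, hydrogen in place of methyl on an aromatic carbon, is a number 6.5 percentage points lower from compound 1 to compound 3 (within the scatter), so the gap between compound 1 and compound 2 seen earlier, which combined both changes, is matched here by the chain change alone and the methyl is not needed to reach this level of inhibition at the dose given. Nothing at hand explains why the entering group has this effect on the read-out.

Which part of the entering group carries the step stays open, and a carboxylic acid, a primary amide or a nitrile on the same chain carbon would help to separate this. A longer chain between the aromatic nitrogen and the entering group is also an open question, and a single-dose read-out leaves the potency of compound 3 undefined.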